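The source may hold more compounds than are shown below. What is called first, only, known or untested is meant among the compounds shown, and "the series" means these compounds.

Measured so far in a functional assay on MGC-803 cells (Homo sapiens) for cytotoxicity, read by MTT assay, with a stated time of 72 h; a lower number here means a stronger inhibitor, a higher number a weaker inhibitor:
compound 1, `Cc1ccc(NC(=O)CSC(=S)N[C@H]2CCOC2=O)cc1`, gives 44300 nM.
compound 2, `O=C(CSC(=S)N[C@H]1CCOC1=O)Nc1cccc([N+](=O)[O-])c1`, gives 58900 nM.
compound 3, `CCSC(=S)N[C@H]1CCOC1=O`, gives only a limit, > 128000 nM.

Compound 3 thus has no number of its own in this assay; its value is the limit described by the limit of > 128000 nM in this assay, at which 1 of the 3 values shown sits, while compounds 1 and 2, the two aryl amide members, each carry a number. Compound 4, `CCCCCCSC(=S)N[C@H]1CCOC1=O`, differs from compound 3 by butyl in place of hydrogen on a saturated chain carbon, two bonds along the chain from a sulfur. Among the compounds with values here, no step between measured compounds is known, so the size expected for this one rests on the change alone: a longer chain on sulfur, still without the aryl amide of compounds 1 and 2. Compound 4 is expected to stay weak, possibly again at a limit. Compound 4 is estimated at 100000 nM, range 40000 nM to 250000 nM, meaning an expected step of an at least 1.2-fold lower number from compound 3 to compound 4 (0.10 log units; that floor lies within the scatter).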

Compound 4, half-maximal inhibitory concentration: > 128000 nM
Compound 4 was reported as a limit; the forecaster's own chance of this, stated with the estimate: 50%; middle value at least 1.2-fold (0.10 log units) away from the limit.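

In this assay compound 3 and compound 4 both stand as limits, so no step between them can be read: the limit of > 128000 nM in this assay, at which 2 of the 4 values shown sit.

The compounds shown leave open whether any chain on sulfur, without the aryl amide of compound 1 and compound 2, gives a measurable value.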